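The source may hold more compounds than are shown below. What is called first, only, known or untested is meant among the compounds shown, and "the series" means these compounds.

Measured so far:
compound 1, `COc1ccc(F)cc1CNCCCNc1ccnc2cc(CCc3ccccc3)ccc12`: 4200 nM
compound 2, `c1ccc(CCc2ccc3c(NCCCNCc4ccco4)ccnc3c2)cc1`: 4200 nM
compound 3, `c1coc(CNCCCNc2ccnc3cc(C4CCCCC4)ccc23)c1`: 4200 nM

In a physicochemical assay for solubility, with a stated time of 18 h, at pH 7.4 (on this read-out lower numbers stand for lower solubility and higher numbers for higher solubility), compound 1 gives 4200 nM, level with compound 2 and compound 3 at the digits shown. The two measured steps, no change at the digits printed from compound 1 to compound 2 (within the scatter) and no change at the digits printed from compound 2 to compound 3 (within the scatter), both stayed within the scatter, the second of them changing a group on the same aromatic carbon of the shared core that is changed here.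

Compound 4, `COc1ccc(F)cc1CNCCCNc1ccnc2cc(-c3ccc(C(C)(C)C)cc3)ccc12`, differs from compound 1 by 4-(tert-butyl)phenyl in place of phenethyl on an aromatic carbon. Among the compounds with values here, no measured step exchanges these two groups, so the expectation rests on the measured steps alone. Since the step from compound 2 to compound 3 at the same place gave no change at the digits printed from compound 2 to compound 3 (within the scatter), the step is expected to be a 1.2-fold lower number from compound 1 to compound 4 (0.08 log units; within the scatter), none beyond the scatter, though a different group enters here and the range is therefore set wide. Compound 4 is thus estimated at 3500 nM in this assay, between 1200 nM and 8000 nM.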

Compound 4, solubility: 32000 nM
Beside the measured number, compound 4's estimate is 9.1-fold (0.96 log units) below it, outside the stated range (above it).
By their numbers in this assay, from the lowest: compounds 1, 2 and 3 (each within the scatter of the next); then compound 4.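

In this assay, this aromatic carbon of the shared core is shown for the first time to matter: putting 4-(tert-butyl)phenyl in place of phenethyl gives a 7.6-fold higher number from compound 1 to compound 4 (0.88 log units; beyond the scatter) and is the first step here beyond the scatter. The earlier change at the same carbon, no change at the digits printed from compound 2 to compound 3 (within the scatter), showed no such movement, so a change here does not always leave the number in place. Both groups hold one six-membered aromatic ring of carbon only and no hydrogen-bond donors or acceptors, and no measurement shown gives a reason for the higher number.

From the compounds shown here alone, whether the rise goes with the tert-butyl group or with the phenyl ring carrying it stays open, and a plain phenyl at this carbon would separate the two. Also open, going by these compounds, is whether an amine or a carboxylic acid in place of the tert-butyl group would give a similar number.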